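Swapping an alkyl chain for a fluorobenzyl group

The source may hold more compounds than are shown below. What is called first, only, known or untested is meant among the compounds shown, and "the series" means these compounds.

Among the compounds with values here, compound 2 `CC(C)CC(C)n1nc(-c2cccs2)c(O)c(C2=NS(=O)(=O)c3cc(NS(C)(=O)=O)ccc3N2)c1=O` is one of two compounds so far tested in an ADME assay on Huh-7 cells (Homo sapiens) for cytotoxicity, with a stated time of 72 h; a lower number here means that less compound is tolerated, a higher number that more compound is tolerated. Compound 1 `CC(C)CCn1nc(-c2cccs2)c(O)c(C2=NS(=O)(=O)c3cc(S(N)(=O)=O)ccc3N2)c1=O` gives > 33000 nM in this assay, which is a limit of the assay rather than a number. Compound 2 gives > 33000 nM in this assay, again a limit and not a number. Both values sit at the same ceiling: the limit of > 33000 nM in this assay, at which 2 of the 2 values shown sit. Compound 3 `CS(=O)(=O)Nc1ccc2c(c1)S(=O)(=O)N=C(c1c(O)c(-c3cccs3)nn(Cc3ccc(F)cc3)c1=O)N2` has not yet been measured in this assay. It differs from compound 2 in one place: 4-fluorobenzyl in place of 1,3-dimethylbutyl on an aromatic nitrogen. Within the data shown here, no measured pair shows what this kind of change does here, so the expected step in this assay is none beyond the scatter, with the limit again the likely outcome. Compound 3 is expected to give 40000 nM in this assay, between 15000 nM and 100000 nM. The step implied by this estimate is a step that the limit leaves unreadable from compound 2 to compound 3.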

Compound 3, half-maximal cytotoxic concentration: > 1000 nM
Compound 3: a limit, no number (the forecaster's own chance of this, stated with the estimate: 80%); the middle value lies beyond the limit too.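

In this assay, within the data shown here, compound 2 and compound 3 each give a limit and not a number, and no step between them can be read. The compounds shown leave open whether 4-fluorobenzyl in place of 1,3-dimethylbutyl changes the concentration these cells tolerate at all.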